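Ester to Pyrrolidine Amide on a Shared Core

This account rests on a few compounds, and the source may have more. Where it says the series, first, only, none or still open, it means among the compounds named here.

Compound 1 `C#Cc1cccc(Nc2ncnc3ccc(NC(=O)Nc4ccc(CN5CCN(C)CC5)cc4)cc23)c1` gives 5170 nM in a functional assay on A549 cells (Homo sapiens) for antiproliferative activity, read by MTT assay, with a stated time of 72 h (a lower number here means a stronger inhibitor, a higher number a weaker inhibitor), and compound 2 `CN1CCN(Cc2ccc(NC(=O)Nc3ccc4ncnc(Nc5cccc(C(F)(F)F)c5)c4c3)cc2)CC1` gives 1650 nM in this assay. Compound 3 `COC(=O)c1cccc(Nc2ncnc3ccc(NC(=O)Nc4ccc(CN5CCN(C)CC5)cc4)cc23)c1` gives only a limit in this assay, > 10000 nM. Its position is thus known only as a floor the limit of > 10000 nM in this assay, at which 1 of the 3 values shown sits: the steps run an at least 6.0-fold higher number from compound 2 to compound 3 (0.78 log units; beyond the scatter) and an at least 1.9-fold higher number from compound 1 to compound 3 (0.28 log units; that floor lies within the scatter). Compound 4 `CN1CCN(Cc2ccc(NC(=O)Nc3ccc4ncnc(Nc5cccc(C(=O)N6CCCC6)c5)c4c3)cc2)CC1` differs from compound 3 by pyrrolidin-1-yl in place of methoxy on a carbonyl carbon. Within the data shown here, no measured step alters the carbonyl substituent itself; the two steps that reach this position both end in methoxycarbonyl and both weaken. The change is therefore expected to be small, a number no higher from compound 3 to compound 4 (the limit leaves the size open), leaving compound 4 near the limit. For compound 4 the estimated inhibitory concentration is 10000 nM, between 3000 nM and 30000 nM.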

Compound 4, half-maximal inhibitory concentration: > 10000 nM
Compound 4: a limit, no number; the forecaster's own chance of this, stated with the estimate: 50%; the middle value sits exactly at the limit.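

In this assay compound 4 gives only a limit, > 10000 nM, so the step from compound 3 to compound 4 cannot be read. With either methoxy or pyrrolidin-1-yl on the carbonyl carbon, the compound now stands at the same limit: the limit of > 10000 nM in this assay, at which 2 of the 4 values shown sit. Measured from the other groups on this aromatic carbon, (pyrrolidin-1-yl)carbonyl gives an at least 6.0-fold higher number from compound 2 to compound 4 (0.78 log units; beyond the scatter), and an at least 1.9-fold higher number from compound 1 to compound 4 (0.28 log units; that floor lies within the scatter).

On these data alone, how far compound 3 and compound 4 lie past the limit, and whether they differ at all, stays open. So does how a carboxylic acid or a primary amine on this aromatic carbon would read in this assay.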